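Methyl Ester to Carboxylic Acid: Little Movement Expected

The source may hold more compounds than are shown below. What is called first, only, known or untested is meant among the compounds shown, and "the series" means these compounds.

The two measured compounds were tested in an assay on cells for displacement of a labelled ligand from Orexin/Hypocretin receptor type 1 (Homo sapiens), read by scintillation counting, with stated times of 10 min and 90 min, tested at 10 uM; a lower number here means less inhibition, a higher number more inhibition at the concentration tested (going by the name of the read-out). Compound 1 `O=C(O)c1ccc2ccc(C(=O)c3ccccc3)c-2cc1` gives 11% in this assay. Among the compounds with values here, compound 2 `CCOc1ccc(-c2cc(C(=O)c3ccccc3)c3ccc(C(=O)OC)ccc2-3)cc1` gives 8.4% in this assay, the lower of the two numbers, though its only neighbour, compound 1, sits a gap away that lies within the usual scatter, so no order between the two can be read from these figures.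

Compound 3 `CCOc1ccc(-c2cc(C(=O)c3ccccc3)c3ccc(C(=O)O)ccc2-3)cc1` differs from compound 2 by hydrogen in place of methyl on an oxygen next to a carbonyl group, the methoxycarbonyl becoming a carboxy group. Within the data shown here, no pair of measured compounds isolates this change, so the step from compound 2 to compound 3 has no measured precedent. Since both measured compounds, with and without the carboxy group, sit low and within the scatter of each other, the expected step of a number 1.6 percentage points higher from compound 2 to compound 3 (within the scatter) is none beyond the scatter. Compound 3 is therefore estimated at 10%, with a range from 0% to 25%.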

Compound 3, a percentage reported as inhibition, at one concentration (the size of the read-out at that concentration, not a potency): -24%
Estimate against measurement, compound 3: 34 percentage points above; measured number below the stated range.
By their numbers in this assay, from the lowest: compound 3; then compounds 2 and 1 (each within the scatter of the next).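

In this assay, hydrogen in place of methyl on an oxygen next to a carbonyl group is not a neutral change on this core: going from methoxycarbonyl to carboxy gives a number 32.4 percentage points lower from compound 2 to compound 3 (beyond the scatter). The carboxy group alone does not set the number, since 4-ethoxyphenyl in place of hydrogen on an aromatic carbon, with the carboxy group present on both sides, gives a number 35 percentage points lower from compound 1 to compound 3 (beyond the scatter). The two steps therefore show that the reading of the carboxy compounds differs with what the core carries elsewhere, and nothing shown here explains either step.

The compounds shown leave open how an ethyl ester or a primary amide in place of the carboxy group would read in this assay. They also leave open whether a plain phenyl or a 4-methoxyphenyl group would behave like 4-ethoxyphenyl.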